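The source may hold more compounds than are shown below. What is called first, only, known or untested is meant among the compounds shown, and "the series" means these compounds.

In a functional assay on MCF7 cells (Homo sapiens) for antiproliferative activity, read by MTT assay, with a stated time of 48 h (on this read-out lower numbers stand for stronger inhibition and higher numbers for weaker inhibition), compound 3 (`CCCCCCCn1cc(COC[C@@H]2OC[C@H](N)[C@H]2O)nn1`) stands at > 128000 nM, which is a limit of the assay and not a number. Compound 4 (`CCCCCCCCCCCCCCn1cc(COC[C@@H]2OC[C@H](N)[C@H]2O)nn1`) keeps the core of compound 3 and differs from it by heptyl in place of hydrogen on a saturated chain carbon, seven bonds along the chain from an aromatic nitrogen. Going by the values given here, only one measured step bears on the chain, and it comes from a core of different stereochemistry. Compound 1 (`CCCCCCCCCn1cc(COC[C@@H]2OC[C@H](N)[C@@H]2O)nn1`) gives 12400 nM and compound 2 (`CCCCCCCCCCn1cc(COC[C@@H]2OC[C@H](N)[C@@H]2O)nn1`) gives 9640 nM, and the step is small: a 1.3-fold lower number from compound 1 to compound 2 (0.11 log units; within the scatter). It says little about a change this large, so the expectation rests mainly on the measurable values of compound 1 and compound 2, and a large move to a lower number in this assay is expected. The expected step is an at least 9.1-fold lower number from compound 3 to compound 4 (0.96 log units; beyond the scatter). For compound 4 the estimated value is 14000 nM, with an expected range of 4000 nM to 70000 nM.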

Compound 4, half-maximal inhibitory concentration: 2450 nM
Compound 4: middle estimate off by 5.7-fold (0.76 log units), on the high side; the measured number lies below the stated range.
By their numbers in this assay, from the lowest: compound 4; then compounds 2 and 1 (each within the scatter of the next). At a limit, above all of these: compound 3.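

On the core of compound 3, heptyl in place of hydrogen at this saturated chain carbon gives an at least 52-fold lower number from compound 3 to compound 4 (1.71 log units; beyond the scatter) in this assay, so here the chain turns an unmeasurable result into a measurable one. The earlier methyl change, a 1.3-fold lower number from compound 1 to compound 2 (0.11 log units; within the scatter), on a core of different stereochemistry, showed no such move. Compound 3 stands at a limit and not a number, so this step has only a lower bound: the limit of > 128000 nM in this assay, at which 1 of the 4 values shown sits.

Going by these compounds, whether a longer chain or a carboxylic acid in place of heptyl would lower the number further stays open. So does whether heptyl at this position gives a step of similar size on the core of compound 1.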